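Indane in Place of Indole: Expected Distribution of Compound 3

A few compounds are considered here, and "the series" means these few. Any claim that something is new, unique, unknown or untested is made for them only; others in the source may bear on it.

This account follows the step from compound 2, `C=CC(=O)Nc1cc(Nc2ncc(Br)c(Nc3ccc4ccn(C)c4c3)n2)c(OC)cc1N1CCN(C)CC1`, to compound 3, `C=CC(=O)Nc1cc(Nc2ncc(Br)c(Nc3ccc4c(c3)CCC4)n2)c(OC)cc1N1CCN(C)CC1`. In an ADME assay on the whole organism (Rattus norvegicus, strain Sprague-Dawley) for pharmacokinetics, read by LC-MS, with a stated time of 24 h, at a dose of 1 mg/kg by the intravenous route (on this read-out lower numbers stand for narrower distribution and higher numbers for wider distribution into tissues), compound 2 gives 6.56 L/kg, the lower of the two numbers available. The other measured compound is compound 1, `CCC(=O)Nc1cc(Nc2ncc(Br)c(Nc3ccc4cc[nH]c4c3)n2)c(OC)cc1N1CCN(C)CC1`, which in this assay gives 7.97 L/kg; the two numbers lie within the scatter of each other, so no order between them can be read.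

Compound 3 is not yet measured in this assay. It differs from compound 2 in one place: 2,3-dihydro-1H-inden-5-yl in place of 1-methyl-1H-indol-6-yl on a nitrogen on an aromatic ring. Within the data shown here, no pair of measured compounds covers this change, so the expectation rests on the value of compound 2 alone. Given that the two measured compounds already sit within the scatter of each other, the step from compound 2 to compound 3 is expected to be a 1.1-fold lower number from compound 2 to compound 3 (0.04 log units; within the scatter), that is, none beyond the scatter. Compound 3 is therefore estimated to give 6 L/kg in this assay, with a range from 3.5 L/kg to 10.5 L/kg.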

Compound 3, volume of distribution at steady state: 4.83 L/kg
The estimate for compound 3 lay 1.2-fold (0.09 log units) above the measured number; the measured number falls inside the stated range.
By their numbers in this assay, from the lowest: compounds 3, 2 and 1 (each within the scatter of the next).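

In this assay, 2,3-dihydro-1H-inden-5-yl in place of 1-methyl-1H-indol-6-yl on a nitrogen on an aromatic ring gives a 1.4-fold lower number from compound 2 to compound 3 (0.13 log units; within the scatter). Among these compounds, this is the first step that differs in one place only, since compound 1 and compound 2 differ in more than one place, and it shows that exchanging a five-membered aromatic ring with 1 hetero atom for a five-membered non-aromatic ring of carbon only leaves the read-out within the scatter. No measurement shown here bears on why this step stays so small.

Going by these compounds, what the compounds leave open is whether this position tolerates other kinds of group equally well: all three carry two-ring groups there, so a single benzene ring bearing a carboxylic acid or a basic amine such as a dimethylaminomethyl group remains untested in these data. On these data alone, whether the same exchange would give a similar step with the rest of the molecule changed also stays open, as this single pair cannot show it.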